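Two Weak Inhibitors and a Rearranged Third

The compounds below may be only part of what the source reports. "The series", "measured", "known", "first", "only" and "open" are said of these compounds alone.

Compound 1 `O=C(NNc1nc2ccccc2nc1Cc1ccccc1)c1ccccc1`: 360000 nM
Compound 2 `COc1ccc(/C=N/NC(=O)Cn2c(=O)c(Cc3ccccc3)nc3ccccc32)cc1`: 82000 nM

In an assay for inhibition of Amine oxidase [flavin-containing] B (Bos taurus), read by fluorescence, with a stated time of 60 min (a higher number here means a weaker inhibitor, a lower number a stronger inhibitor), compound 2 gives the lower of the two numbers, and compound 1 sits a step above it that lies beyond the usual scatter. Compound 3 `C/C(=N\NC(=O)Cn1c(=O)c(Cc2ccccc2)nc2ccccc21)c1ccc(O)cc1` keeps the same atoms as compound 2 but joins them differently: a group of 10 heavy atoms (8 carbon, 1 nitrogen, 1 oxygen; one six-membered aromatic ring of carbon only) in place of a group of 10 heavy atoms (8 carbon, 1 nitrogen, 1 oxygen; one six-membered aromatic ring of carbon only), on an amide-type nitrogen. Among the compounds with values here, no step between measured compounds guides the size of such a rearrangement. The expected change is a 1.0-fold lower number from compound 2 to compound 3 (0.01 log units; within the scatter), no larger than the scatter of this assay in either direction. Compound 3 is estimated at 80000 nM, with a range of 30000 nM to 250000 nM.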

Compound 3, half-maximal inhibitory concentration: 980000 nM
Compound 3: middle estimate off by 12-fold (1.09 log units), on the low side; the whole stated range lies below it.
By their numbers in this assay, from the lowest: compound 2; then compound 1; then compound 3.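

In this assay the rearrangement on the amide-type nitrogen gives a 12-fold higher number from compound 2 to compound 3 (1.08 log units; beyond the scatter) even though the leaving and entering groups have the same heavy atoms and the same six-membered aromatic ring of carbon only. The entering group counts 1 hydrogen-bond donor where the leaving group counts 0, so the same atoms at this place do not ensure a similar number. Nothing measured here explains the step. The compounds shown leave open whether the donor or the rearranged connectivity matters, and how a group carrying an amine or a carboxylic acid would read at this place.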